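The compounds below may be only part of what the source reports. "The series", "measured", "known", "first", "only" and "open" are said of these compounds alone.

Compound 1 `O=C(CSc1nc2c(c(=O)n1-c1ccccc1)SCC2)Nc1ccc(-c2cncnc2)cn1` and compound 2 `O=C(CSc1nc2c(c(=O)n1-c1ccccc1)SCC2)Nc1ccc(-c2ccccc2)nc1` share one core and were both tested in an assay on L cells for inhibition of Protein-serine O-palmitoleoyltransferase porcupine (Mus musculus), read by reporter gene assay, with a stated time of 24 h; on this read-out lower numbers stand for an effect already at smaller amounts and higher numbers for an effect only at larger amounts of compound. Compound 1 gives 5.5 nM in this assay, the highest of the two numbers, while compound 2 gives 0.3 nM, a lower number by a margin beyond the usual scatter. The two differ in more than one place, so their values are reported side by side without a single step between them.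

Compound 3 `O=C(CSc1nc2c(c(=O)n1-c1ccccc1)SCC2)Nc1ccc(-c2ccco2)cn1` is the unmeasured partner of compound 1. It carries the change (furan-2-yl in place of pyrimidin-5-yl on an aromatic carbon), that is, furan-2-yl in place of pyrimidin-5-yl on an aromatic carbon. Going by the values given here, no measured pair shows what this exchange does at this place, so the expectation rests on the two values alone. The step from compound 1 to compound 3 is expected to be small, toward a lower number, at most near the scatter, as a 1.8-fold lower number from compound 1 to compound 3 (0.26 log units; within the scatter). Compound 3 is estimated to give 3 nM in this assay, with a range from 0.8 nM to 12 nM.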

Compound 3, half-maximal effective concentration: 3.5 nM
The estimate for compound 3 lay 1.2-fold (0.07 log units) below the measured number; the range from low to high includes it.
By their numbers in this assay, from the lowest: compound 2; then compounds 3 and 1 (each within the scatter of the next).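

Going by these compounds alone, this is the first step at this place that changes one group alone: in this assay, furan-2-yl in place of pyrimidin-5-yl on the aromatic carbon two atoms from the ring nitrogen gives a 1.6-fold lower number from compound 1 to compound 3 (0.20 log units; within the scatter) and so leaves compound 1 and compound 3 indistinguishable. A five-membered aromatic ring with one hetero atom and a single hydrogen-bond acceptor can therefore stand here in place of a six-membered aromatic ring with two hetero atoms and two acceptors, with no difference that can be read in this assay. Nothing measured here offers an explanation for this result.

On these data alone, what an amine or a carboxylic acid at this place would do remains open. The compounds shown also do not separate the places in which compound 2 differs from compound 1.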